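The source may report more compounds than this note shows. Statements on the series, on what has been measured and on what is new or still open speak of the compounds shown alone.

Three compounds from this study share a chromane-type core bearing a urea or thiourea side chain, and a fourth is still to be tested.

Compound 1 `CC1(C)CC(NC(=O)NCc2ccccc2)c2cc(Cl)ccc2O1` is the weakest of the three in a functional assay on U-373MG ATCC cells (Homo sapiens) for inhibition, read by MTT assay, with a stated time of 72 h; on this read-out lower numbers stand for stronger inhibition and higher numbers for weaker inhibition; compound 1 gives 66000 nM. Compound 2 `CC1(C)CC(NC(=O)NCc2ccccc2)c2cc(F)ccc2O1` differs from it only by fluoro in place of chloro on an aromatic carbon, and in this assay compound 2 gives 11000 nM. That single change made a 6.0-fold lower number from compound 1 to compound 2 (0.78 log units; beyond the scatter).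

Compound 3 `CC1(C)CC(NC(=S)Nc2cccc([N+](=O)[O-])c2)c2cc(Cl)ccc2O1` carries a different side chain and a nitro group on its aryl ring; how its core differs from that of compound 1 is not broken down here. In this assay compound 3 gives 3000 nM, the lowest number of the three.

Compound 4 `CC1(C)CC(NC(=S)Nc2cccc([N+](=O)[O-])c2)c2cc(F)ccc2O1` differs from compound 3 only by fluoro in place of chloro on an aromatic carbon. This is the same change already seen between compound 1 and compound 2, made at the same place on the core. If it carries over, the step from compound 3 to compound 4 in this assay is expected to be a 3.8-fold lower number from compound 3 to compound 4 (0.57 log units; beyond the scatter), resting on the step seen from compound 1 to compound 2. That step is a single observation, and the two side chains differ. The expectation is held loosely. Compound 4 is therefore estimated at 800 nM, with a plausible range from 250 nM to 3000 nM.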

Compound 4, half-maximal inhibitory concentration: 6000 nM
The estimate for compound 4 lay 7.5-fold (0.88 log units) below the measured number, and the stated range ends below it.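

In this assay, putting fluoro in place of chloro on the thiourea side chain gives a 2.0-fold higher number from compound 3 to compound 4 (0.30 log units; within the scatter), so on this pair the change has no effect that can be told apart from the usual scatter of repeated measurements. Set beside the earlier pair, the same change at the same place does not give the same result on the two cores: the same change on two cores in this assay, a 6.0-fold lower number (0.78 log units; beyond the scatter) from compound 1 to compound 2 and a 2.0-fold higher number (0.30 log units; within the scatter) from compound 3 to compound 4, 12-fold (1.08 log units) apart, beyond the scatter of two such steps. For the compounds shown here, this shows that, in this series, the step seen on one core cannot simply be transferred to another, but with only two pairs it does not show which feature of the side chain separates them, nor does it establish that fluoro is generally better or worse than chloro.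

The two side chains differ in more than one respect, as urea against thiourea, and as a benzyl group against an aryl ring with a nitro group, so the compounds shown leave open which of these differences matters for the step. They also leave open how a bromo or a methoxy group on that same aromatic carbon would compare with chloro and fluoro on each side chain.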